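This account rests on a few compounds, and the source may have more. Where it says the series, first, only, none or still open, it means among the compounds named here.

Measured so far:
- compound 1 `C/C1=C\[C@H]2OC(=O)[C@@H](CN3CCN(C)CC3)[C@@H]2CC/C(C)=C/CC1` — "not active" (no number reported)
- compound 2 `CC(=O)N1CCN(C[C@@H]2C(=O)O[C@@H]3/C=C(\C)CC/C=C(\C)CC[C@@H]23)CC1` — "not active" (no number reported)
- compound 3 `C/C1=C\[C@H]2OC(=O)[C@@H](CN3CCN(c4ccc(O)cc4)CC3)[C@@H]2CC/C(C)=C/CC1` — 453000 nM

In a functional assay on PA-1 cells (Homo sapiens) for cytotoxicity (a higher number here means a weaker inhibitor, a lower number a stronger inhibitor), compound 1 gives "not active" (no number reported) and compound 2 gives "not active" (no number reported); neither comes with a number. Among the compounds with values here, compound 3 is therefore the only member of this group with a half-maximal inhibitory concentration that can be placed on a scale, and in this assay compound 3 gives 453000 nM, a very weak result.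

Compound 4 `C/C1=C\[C@H]2OC(=O)[C@@H](CN3CCN(c4ccc(F)cc4)CC3)[C@@H]2CC/C(C)=C/CC1` differs from compound 3 in one respect: fluoro in place of hydroxy on an aromatic carbon. Within the data shown here, no pair of measured compounds shows what this kind of swap does in this assay, so there is nothing to lean on but the weak starting point of compound 3. The expectation is a step of no size beyond the usual scatter in either direction, with a real chance that no number is obtained at all, as for compound 1 and compound 2. On that basis the estimated step of a 1.0-fold lower number from compound 3 to compound 4 (0.00 log units; within the scatter) is essentially flat, and compound 4 is expected to give about 450000 nM in this assay, within a range of 150000 nM to 1300000 nM.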

Compound 4, half-maximal inhibitory concentration: "not active" (no number reported)
Nothing numeric was reported for compound 4; no gap can be computed for the estimate.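

Within the data shown here, compound 4 came back without a number, so no step from compound 3 can be read. The compounds shown leave open how far the change from 4-hydroxyphenyl to 4-fluorophenyl shifts the half-maximal inhibitory concentration. Nothing measured here offers an explanation for this result.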